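Expected half-life after swapping the ring group in compound 1

This account rests on a few compounds, and the source may have more. Where it says the series, first, only, none or still open, it means among the compounds named here.

- Compound 1 `CC(C)C(/C=C1\NC(=O)NC1=O)c1ccc(-c2ccc3cccc(F)c3c2)[nH]c1=O` gives > 3 h as a limit in an ADME assay on microsomes from liver (Homo sapiens) for metabolic stability; on this read-out lower numbers stand for a shorter-lived compound and higher numbers for a longer-lived compound
- Compound 2 `CC(C)/C(=C1/SC(=O)NC1=O)c1ccc(-c2ccc3cccc(F)c3c2)[nH]c1=O` gives > 3 h as a limit in this assay

Compound 1 has no exact number and stands on the limit of > 3 h in this assay, at which 2 of the 2 values shown sit, as its only reference point. Compound 3 `CC(C)C(c1ccc(-c2ccc3cccc(F)c3c2)[nH]c1=O)C1C(=O)NC(=O)N1C` has not yet been measured. Its structure differs from that of compound 1 as follows: a group of 8 heavy atoms (4 carbon, 2 nitrogen, 2 oxygen; one five-membered non-aromatic ring with 2 hetero atoms) in place of a group of 8 heavy atoms (4 carbon, 2 nitrogen, 2 oxygen; one five-membered non-aromatic ring with 2 hetero atoms), on a saturated chain carbon bound to an aromatic carbon and a saturated chain carbon and the group that enters is 3-methyl-2,5-dioxoimidazolidin-4-yl, on a saturated chain carbon bound to an aromatic carbon and a saturated chain carbon. Within the data shown here, no measured step exists to gauge such a change, and the direction stays open. In this assay the expected change is a number no higher from compound 1 to compound 3 (the limit leaves the size open) and nothing beyond the usual scatter is expected. That expectation rests on compound 1 with its > 3 h (a limit). Compound 3 is estimated at 3 h (expected range 1.5 h to 6 h).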

Compound 3, half-life: 0.375 h
Estimate against measurement, compound 3: 8.0-fold (0.90 log units) above, outside the stated range (below it).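

At the saturated chain carbon bound to an aromatic carbon and a saturated chain carbon, the ring group matters in this assay, as 3-methyl-2,5-dioxoimidazolidin-4-yl in place of the group of compound 1 gives an at least 8.0-fold lower number from compound 1 to compound 3 (0.90 log units; beyond the scatter). Compound 3 is the only compound shown with an exact number, so it shows that a change at this place can bring the half-life clear of the limit shared by compound 1 and compound 2. The true size of the step stays open, since compound 1 stands only on a limit: the limit of > 3 h in this assay, at which 2 of the 3 values shown sit.

The compounds shown leave open which part of the exchange carries the drop, the 3-methyl group or the count of double bonds outside aromatic rings and of hydrogen-bond donors. They also leave open how a carboxylic acid or an amine at this place would fare.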